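Tert-butyl for phenyl in a cytotoxicity series

A few compounds are considered here, and "the series" means these few. Any claim that something is new, unique, unknown or untested is made for them only; others in the source may bear on it.

Three analogues share one core and differ only in the group on the outer benzyl ring. Compound 1 `COC(=O)c1ccc(NCc2cncn2Cc2cccc(C)c2)cc1-c1ccccc1` was tested in a toxicity assay on NIH3T3 cells (Mus musculus) for cytotoxicity, read by resazurin assay; on this read-out lower numbers stand for an effect already at smaller amounts and higher numbers for an effect only at larger amounts of compound. For compound 1 the result is a limit of the assay, > 10000 nM, not a number. Compound 2 `COC(=O)c1ccc(NCc2cncn2Cc2cccc(OC)c2)cc1-c1ccccc1` shows "not determined" (no result reported) in this assay. Compound 3 `COC(=O)c1ccc(NCc2cncn2Cc2cccc(-c3ccccc3)c2)cc1-c1ccccc1` likewise shows "not determined" (no result reported) in this assay, so compound 3 stands without a number of its own; of the three entries shown, one sits at the limit of > 10000 nM in this assay, at which 1 of the 3 values shown sits, and the other two are blank. Compound 4 `COC(=O)c1ccc(NCc2cncn2Cc2cccc(C(C)(C)C)c2)cc1-c1ccccc1` differs from compound 3 by tert-butyl in place of phenyl on an aromatic carbon. For the measured compounds named here, no measured step exists here, and the expectation rests on the limit of compound 1. Compound 4 is expected to lie at or near the upper limit of this assay, at an estimated 15000 nM, within 5000 nM to 50000 nM.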

Compound 4, half-maximal effective concentration: > 1000 nM
Compound 4: a limit, no number (the forecaster's own chance of this, stated with the estimate: 70%); the middle value does not contradict the limit.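

For the compounds shown here, compound 1 and compound 4 both end in limits of the assay, so no step between them can be read in this assay. The compounds shown leave open whether any group on the outer benzyl ring gives an actual number rather than a limit.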